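The source may hold more compounds than are shown below. What is called first, only, known or untested is meant among the compounds shown, and "the series" means these compounds.

Of the compounds shown here, two of a shared core have been measured in an assay on Sf9 cells for inhibition of serine/threonine-protein kinase 4 (Homo sapiens), read by luminescence and ADP-Glo, with a stated time of 1 h, in the presence of a further agent that is not named here; a lower number here means a stronger inhibitor, a higher number a weaker inhibitor. Compound 1 `CN1C(=O)C(c2ccccc2)N(C)c2nc(Nc3ccc(S(N)(=O)=O)cc3)ncc21` is the plainest of the pair: it carries a phenyl group on a saturated ring carbon of its core, and in this assay compound 1 gives 383 nM. That is the highest of the two numbers seen so far, so compound 1 is the weaker inhibitor of the two. Compound 2 `CN1C(=O)C(c2ccccc2F)N(C)c2nc(Nc3ccc(S(N)(=O)=O)cc3)ncc21` differs from it only by a fluoro in place of hydrogen on an aromatic carbon, and in this assay compound 2 gives 75 nM; the step is a 5.1-fold lower number from compound 1 to compound 2 (0.71 log units; beyond the scatter).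

Compound 3 `Cc1c(F)cccc1C1C(=O)N(C)c2cnc(Nc3ccc(S(N)(=O)=O)cc3)nc2N1C` has not yet been measured. Relative to compound 1 its change is 3-fluoro-2-methylphenyl in place of phenyl on a saturated ring carbon. Among the compounds with values here, the only measured step that speaks to this is the one from compound 1 to compound 2, where adding a single fluorine gave a modest improvement beyond the scatter. The new group also carries a fluorine, now with a methyl group as well, so a step of a similar kind and direction is expected, though its size is uncertain because the fluorine sits at a different position and the methyl group is new. The expected step is a 3.5-fold lower number from compound 1 to compound 3 (0.54 log units; beyond the scatter). Compound 3 is therefore estimated to give 110 nM, with a likely range from 40 nM to 300 nM.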

Compound 3, half-maximal inhibitory concentration: 419 nM
The estimate for compound 3 lay 3.8-fold (0.58 log units) below the measured number, and the stated range ends below it.
By their numbers in this assay, from the lowest: compound 2; then compounds 1 and 3 (each within the scatter of the next).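

Placing 3-fluoro-2-methylphenyl on the saturated ring carbon in place of phenyl leaves the result in this assay essentially unchanged, with a 1.1-fold higher number from compound 1 to compound 3 (0.04 log units; within the scatter). This shows that a fluorine on the phenyl ring does not bring a gain in every setting at this position: the step from 2-fluorophenyl to the new group is a 5.6-fold higher number from compound 2 to compound 3 (0.75 log units; beyond the scatter), so compound 2 remains the only clearly stronger inhibitor of the three. The data offer no measurement that explains why two fluorine-bearing groups at the same position give such different numbers.

The new group differs from 2-fluorophenyl in both its methyl group and the place of its fluorine, so the compounds shown cannot separate what each of these changes contributes, and 2-methylphenyl and 3-fluorophenyl would be the simplest groups for telling them apart. Also open is how this position would respond to a group of a different kind on the phenyl ring, such as an amine or a carboxylic acid, since every group shown here is a phenyl ring bearing only fluorine or methyl, or nothing at all.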